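The source may hold more compounds than are shown below. What is called first, only, known or untested is meant among the compounds shown, and "the series" means these compounds.

In an assay on cells (Hepatocyte) for inhibition of glucokinase regulatory protein (Mus musculus), with stated times of 20 min and 40 min (on this read-out higher numbers stand for an effect only at larger amounts of compound and lower numbers for an effect already at smaller amounts), compound 1 `CC#C[C@H]1CN(S(=O)(=O)c2ccc(N)nc2)CCN1c1ccc([C@@](O)(CO)C(F)(F)F)cc1` gives 89 nM, and compound 2 `CC#C[C@H]1CN(S(=O)(=O)c2ccc(N)nc2)CCN1c1ccc(S(=N)(=O)C2CC2)cc1` gives 208 nM. Compound 2 thus stands highest of the two numbers, the step of a 2.3-fold higher number from compound 1 to compound 2 (0.37 log units; beyond the scatter) lying beyond the scatter. Compound 3 `CC#C[C@H]1CN(S(=O)(=O)c2ccc(N)nc2)CCN1c1ccc(C(=O)NC)cc1` differs from compound 2 in one place: a group of 4 heavy atoms (2 carbon, 1 nitrogen, 1 oxygen; no ring) in place of a group of 6 heavy atoms (3 carbon, 1 nitrogen, 1 oxygen, 1 sulfur; one three-membered non-aromatic ring of carbon only), on an aromatic carbon. Going by the values given here, no measured step exchanges the group that leaves here for the one that enters; the one step known, from compound 1 to compound 2, changed a different group at that place and was modest. Compound 3 is therefore expected near 250 nM, within 80 nM to 800 nM. For compound 3 this means an expected step of a 1.2-fold higher number from compound 2 to compound 3 (0.08 log units; within the scatter).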

Compound 3, half-maximal effective concentration: 4050 nM
Compound 3: the middle estimate sits 16-fold (1.21 log units) below what was measured; measured number above the stated range.
By their numbers in this assay, from the lowest: compound 1; then compound 2; then compound 3.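

In this assay this position proves far less forgiving than the first pair suggested: methylcarbamoyl gives a 19-fold higher number from compound 2 to compound 3 (1.29 log units; beyond the scatter) and also a 46-fold higher number from compound 1 to compound 3 (1.66 log units; beyond the scatter) in the two comparisons, both well beyond a 2.3-fold higher number from compound 1 to compound 2 (0.37 log units; beyond the scatter) in size. Across these three compounds the number rises as the group at this place holds fewer heavy atoms, and none of them goes against that order. No measurement shown accounts for the jump.

On these data alone, whether size or the kind of group governs the number stays open. A carboxylic acid, a tertiary amide or a longer chain on the amide nitrogen would help separate the two.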